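Moving the Fluorine on a Compound Sitting at the Limit

The source may report more compounds than this note shows. Statements on the series, on what has been measured and on what is new or still open speak of the compounds shown alone.

Two related compounds have been tested so far in an ADME assay on THP-1 cells (Homo sapiens) for cytotoxicity, read by flow cytometry and propidium iodide staining, with a stated time of 72 h; on this read-out higher numbers stand for weaker inhibition and lower numbers for stronger inhibition. Compound 1 (`CC(=O)Nc1ccc2oc(-c3cccc(F)c3)cc(=O)c2c1`) gives > 125000 nM, which is a limit of the assay and not a number. Compound 2 (`COc1c(-c2ccccc2F)oc2ccc(NC(C)=O)cc2c1=O`) gives > 125000 nM, and this too is a limit rather than a number. The record so far is therefore (the limit of > 125000 nM in this assay, at which 2 of the 2 values shown sit).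

Compound 3 (`COc1c(-c2cccc(F)c2)oc2ccc(NC(C)=O)cc2c1=O`) has not yet been measured. It has the same atoms as compound 2, joined differently: 3-fluorophenyl stands in place of 2-fluorophenyl on an aromatic carbon, ortho to a methoxy group. The change is 3-fluorophenyl in place of 2-fluorophenyl on an aromatic carbon.

Among the compounds with values here, no measured step between two compounds is available to show how large such a change might be. With only a limit for compound 2 as a starting point, no shift beyond the usual scatter is expected. The estimated step is a number no higher from compound 2 to compound 3 (the limit leaves the size open). For compound 3, the expected value in this assay is 125000 nM, with an estimated range from 60000 nM to 250000 nM.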

Compound 3, half-maximal inhibitory concentration: > 125000 nM
Compound 3: only a limit was reported (the forecaster's own chance of this, stated with the estimate: 85%); the middle value sits exactly at the limit.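

No step can be read from compound 2 to compound 3 or from compound 1 to compound 3, because each of the three compounds gives a limit of the assay and not a number: the limit of > 125000 nM in this assay, at which 3 of the 3 values shown sit.

The compounds shown leave open whether the place of the fluorine or the methoxy group makes any difference in this assay.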